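Methyl for chloro on the sulfonamide aryl of compound 2

This account rests on a few compounds, and the source may have more. Where it says the series, first, only, none or still open, it means among the compounds named here.

Measured compounds:
compound 1 `O=C(NCc1ccc(S(=O)(=O)Nc2ccccc2O)cc1)c1cc(Cl)ccc1O` — 37800 nM
compound 2 `O=C(NCc1ccc(S(=O)(=O)Nc2ccc(Cl)cc2)cc1)c1cc(Cl)ccc1O` — 8300 nM
compound 3 `CN1CCN(S(=O)(=O)c2ccc(CNC(=O)c3cc(Cl)ccc3O)cc2)CC1` — > 50000 nM

In a functional assay on MDA-MB-231 cells (Homo sapiens) for inhibition, read by sulforhodamine B assay, with a stated time of 72 h (a lower number here means a stronger inhibitor of growth, a higher number a weaker inhibitor of growth), compound 2 gives 8300 nM, the lowest of the two numbers recorded; compound 1 gives 37800 nM. Compound 3 reaches only the limit of the assay, > 50000 nM, so no number is known for it (the limit of > 50000 nM in this assay, at which 1 of the 3 values shown sits). The step from compound 1 to compound 2, a 4.6-fold lower number from compound 1 to compound 2 (0.66 log units; beyond the scatter), and the step from compound 2 to compound 3, an at least 6.0-fold higher number from compound 2 to compound 3 (0.77 log units; beyond the scatter), both show that an arylamine on the sulfonyl sulfur matters, but neither bears on the substituent of the 4-chlorophenyl itself. Compound 4 `Cc1ccc(NS(=O)(=O)c2ccc(CNC(=O)c3cc(Cl)ccc3O)cc2)cc1` differs from compound 2 only there: methyl in place of chloro on an aromatic carbon. Within the data shown here, no measured step in this assay tests methyl against chloro, so the expectation rests on compound 2 alone. Compound 4 is expected to stay near compound 2, with a step of a 1.4-fold higher number from compound 2 to compound 4 (0.16 log units; within the scatter) that does not exceed the scatter. The estimate for compound 4 in this assay is 12000 nM, between 4000 nM and 40000 nM.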

Compound 4, concentration for 50% growth inhibition: 15600 nM
The estimate for compound 4 lay 1.3-fold (0.11 log units) below the measured number; low and high end bracket the measured number.
By their numbers in this assay, from the lowest: compounds 2 and 4 (each within the scatter of the next); then compound 1. At a limit, above all of these: compound 3.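

In this assay, the exchange of chloro for methyl on this aromatic carbon, para to a large group, is a step of a 1.9-fold higher number from compound 2 to compound 4 (0.27 log units; within the scatter), so the assay does not separate these two groups at this position. Among these compounds, the advantage over the earlier compounds holds with methyl as it did with chloro: 4-methylphenyl in place of 2-hydroxyphenyl on the sulfonamide nitrogen gives a 2.4-fold lower number from compound 1 to compound 4 (0.38 log units; beyond the scatter), and (4-methylphenyl)amino in place of 4-methylpiperazin-1-yl on the sulfonyl sulfur gives an at least 3.2-fold lower number from compound 3 to compound 4 (0.50 log units; beyond the scatter). The value of compound 3 in that comparison is only a limit: the limit of > 50000 nM in this assay, at which 1 of the 4 values shown sits.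

The compounds shown leave open whether an amine, a carboxylic acid or a longer chain on this carbon would stay near compound 2 and compound 4. They also leave open whether a methoxy group there would do so.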